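A few compounds are considered here, and "the series" means these few. Any claim that something is new, unique, unknown or untested is made for them only; others in the source may bear on it.

Going by the values given here, compound 2, `CCS(=O)(=O)Nc1ccc2c(c1)/C(=C(/Nc1ccccc1)c1ccccc1)C(=O)N2`, is one of two compounds measured in an ADME assay on HepG2 cells (Homo sapiens) for cytotoxicity, read by MTT assay, with a stated time of 48 h (on this read-out lower numbers stand for higher toxicity in this test and higher numbers for lower toxicity in this test), where compound 2 gives 4.7 uM. Among the compounds with values here, the only other measured compound, compound 1, `CCS(=O)(=O)Nc1ccc2c(c1)/C(=C(/Nc1ccc(C)cc1)c1ccccc1)C(=O)N2`, gives 3.1 uM in this assay, and the step of a 1.5-fold higher number from compound 1 to compound 2 (0.18 log units; within the scatter) leaves the two within the usual scatter of each other, so compound 2 is not distinguished from compound 1 on these numbers. Compound 3, `CCS(=O)(=O)Nc1ccc2c(c1)/C(=C(/Nc1ccc(N3CCCCC3)cc1)c1ccccc1)C(=O)N2`, has not yet been measured. It differs from compound 2 in a single place: piperidin-1-yl in place of hydrogen on an aromatic carbon. Within the data shown here, the one measured step, from compound 1 to compound 2, concerns the same aromatic carbon, but there the exchange was only between methyl and hydrogen, and it stayed within the scatter; no measured step follows the entry of a six-membered ring at this place. The account therefore expects, with little evidence to lean on, a step of a 1.2-fold lower number from compound 2 to compound 3 (0.07 log units; within the scatter) that does not clearly leave the scatter. The estimate for compound 3 in this assay is 4 uM, with a range from 1.3 uM to 12 uM.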

Compound 3, half-maximal toxic concentration: > 6 uM
Compound 3 gave a limit, no number; the forecaster's own chance of this, stated with the estimate: 5%; middle value at least 1.5-fold (0.17 log units) away from the limit.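

Until now this aromatic carbon had carried only hydrogen and methyl; with compound 3 it carries a six-membered non-aromatic ring, and the read-out gives no sign of higher toxicity in this test. In this assay the result for compound 3 is a limit and not a number: the limit of > 6 uM in this assay, at which 1 of the 3 values shown sits. The steps can therefore be read only as floors, an at least 1.2-fold higher number from compound 2 to compound 3 (0.10 log units; that floor lies within the scatter) and an at least 1.9-fold higher number from compound 1 to compound 3 (0.28 log units; that floor lies within the scatter), so piperidin-1-yl is not shown to separate compound 3 from either compound, and the true size of both steps stays unknown.

The compounds shown leave open whether other groups at this place, such as morpholin-4-yl, dimethylamino or a carboxylic acid, would read like piperidin-1-yl or would move the number towards higher toxicity in this test. They also leave open whether the ring or its nitrogen matters more, a question that a cyclohexyl group at the same carbon would bear on.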